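The compounds below may be only part of what the source reports. "The series", "measured", "known", "first", "only" and "open" are said of these compounds alone.

Of the compounds shown here, three sharing one core have been measured in a physicochemical assay for solubility, read by nephelometry, in phosphate buffer, measured as kinetic solubility, at pH 6.5; a lower number here means a less soluble compound, a higher number a more soluble compound. Compound 1 `COc1ccc(-c2cc(-c3ccc(S(=O)(=O)NC4CC4)cc3)cnc2N)cn1` gives 6.3 ug/mL. Compound 2 `COc1ccc(-c2cc(-c3ccc(NS(C)(=O)=O)cc3)cnc2N)cn1` gives 25 ug/mL, and compound 3 `COc1ccc(-c2cc(-c3ccc(-n4cncn4)cc3)cnc2N)cn1` gives 6.3 ug/mL. Compound 3 thus stands level with compound 1, the two together at the bottom of the three numbers, while compound 2 sits higher, as a 4.0-fold lower number from compound 2 to compound 3 (0.60 log units; beyond the scatter) shows; the comparison no change at the digits printed from compound 1 to compound 3 (within the scatter) adds nothing beyond the scatter.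

Compound 4 `COc1ccc(-c2cc(-c3ccc(C(N)=O)cc3)cnc2N)cn1` differs from compound 3 in one place: carbamoyl in place of 1H-1,2,4-triazol-1-yl on an aromatic carbon. Going by the values given here, the steps that bear on this are a 4.0-fold lower number from compound 2 to compound 3 (0.60 log units; beyond the scatter) and no change at the digits printed from compound 1 to compound 3 (within the scatter), both modest or within the scatter. Among the compounds with values here, since the entering carbamoyl, like the methanesulfonamido of compound 2, carries a hydrogen-bond donor, a rise of similar modest size is expected rather than none, though the data hold no direct precedent for carbamoyl. The expected step is a 2.1-fold higher number from compound 3 to compound 4 (0.31 log units; beyond the scatter). Compound 4 is therefore estimated at 13 ug/mL, with a range from 5 ug/mL to 32 ug/mL.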

Compound 4, solubility: 12.5 ug/mL
Estimate against measurement, compound 4: 1.0-fold (0.02 log units) above, within the range that was stated.
By their numbers in this assay, from the lowest: compounds 1, 3, 4 and 2 (each within the scatter of the next, the first and the last beyond it).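

In this assay, carbamoyl on this aromatic carbon gives a 2.0-fold higher number from compound 3 to compound 4 (0.30 log units; within the scatter), while the other two comparisons give a 2.0-fold higher number from compound 1 to compound 4 (0.30 log units; within the scatter) and a 2.0-fold lower number from compound 2 to compound 4 (0.30 log units; within the scatter). Compound 4 therefore cannot be separated from any of the other three compounds, even though compound 2 and compound 3 are separated from each other, so this small group without a ring cannot be assigned to either level. Nothing available explains these numbers.

From the compounds shown here alone, it remains open whether a carboxylic acid, a primary amine or a nitrile at this same place would stay within the range of these four compounds or move clearly outside it. Going by these compounds, it also remains open whether the same replacements would give similar steps on a core other than the shared one.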